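Methoxy on compound 2: expected step to compound 4

This account rests on a few compounds, and the source may have more. Where it says the series, first, only, none or still open, it means among the compounds named here.

Among the compounds with values here, in an ADME assay on Vero cells (Chlorocebus sabaeus) for cytotoxicity, read by MTT assay, with a stated time of 72 h (on this read-out lower numbers stand for higher toxicity in this test and higher numbers for lower toxicity in this test), compound 2 `CCO/N=C1\C(=O)N(CCCOc2ccc3oc(-c4ccc(OC)cc4)c(C(=O)OCC)c3c2)c2ccccc21` gives 16 ug/mL, the lowest of the three numbers measured so far. Compound 1 `CCOC(=O)c1c(-c2ccc(OC)cc2)oc2ccc(OCCCN3C(=O)/C(=N\OC)c4ccccc43)cc12` gives 128 ug/mL, and compound 3 `CCOC(=O)c1c(-c2ccc(OC)cc2)oc2ccc(OCCCCCCN3C(=O)C(=O)c4cc(F)ccc43)cc12` gives 1020 ug/mL.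

Compound 4 `CCO/N=C1\C(=O)N(CCCOc2ccc3oc(-c4ccc(OC)cc4)c(C(=O)OCC)c3c2)c2ccc(OC)cc21` differs from compound 2 in one place: methoxy in place of hydrogen on an aromatic carbon. This is methoxy in place of hydrogen on an aromatic carbon, on a six-membered aromatic ring of carbon only that is part of a fused or bridged system of two rings.

Within the data shown here, only one measured step is available as a guide: an 8.0-fold lower number from compound 1 to compound 2 (0.90 log units; beyond the scatter). It is methyl in place of hydrogen on a saturated chain carbon bound to an oxygen on an unsaturated carbon. That step lies beyond the scatter, but it sits at a different place, so it bears on this change only loosely. Among the measured compounds shown here, no measured pair isolates a change on the aromatic ring in question.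

With the starting point at the bottom of the measured numbers, a slightly higher number is expected, and a lower one is not excluded. The estimated step is a 1.9-fold higher number from compound 2 to compound 4 (0.27 log units; within the scatter). For compound 4 the expected value is 30 ug/mL, with an estimated range of 8 ug/mL to 130 ug/mL.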

Compound 4, half-maximal cytotoxic concentration: 32 ug/mL
Beside the measured number, compound 4's estimate is 1.1-fold (0.03 log units) below it, and the stated range covers the measured number.
By their numbers in this assay, from the lowest: compounds 2 and 4 (each within the scatter of the next); then compound 1; then compound 3.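

In this assay, within the data shown here, methoxy in place of hydrogen on an aromatic carbon of the six-membered aromatic ring of carbon only gives a 2.0-fold higher number from compound 2 to compound 4 (0.30 log units; within the scatter) and so adds a first reading at this ring, where the step stays within the scatter. Among these compounds, the only earlier step, an 8.0-fold lower number from compound 1 to compound 2 (0.90 log units; beyond the scatter), is methyl in place of hydrogen on a saturated chain carbon bound to an oxygen on an unsaturated carbon, and it lies beyond the scatter at a different place. Nothing available explains the result at this position, and this single pair gives no basis for a trend across the ring.

Whether an amine or a carboxylic acid on this aromatic carbon would also stay within the scatter of compound 2 remains open, since the compounds shown carry only hydrogen and methoxy here. Also open, on these data alone, is whether methoxy at this place would give a step of similar size on compound 1, which lacks the methyl on the saturated chain carbon, or at the other aromatic carbons of the same ring.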